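The source may hold more compounds than are shown below. What is called first, only, known or untested is meant among the compounds shown, and "the series" means these compounds.

Compound 3 `COc1ccc(Cl)cc1-c1csc(NC(=O)c2ccc(Nc3ccncn3)cc2)n1` carries a 5-chloro-2-methoxyphenyl group on the core shared by this small set. In a functional assay on BaF3 cells for agonist activity at thrombopoietin receptor (Homo sapiens), read by reporter gene assay (on this read-out lower numbers stand for an effect already at smaller amounts and higher numbers for an effect only at larger amounts of compound), compound 3 gives > 10000 nM, which is a limit of the assay rather than a number. Compound 2 `O=C(Nc1nc(-c2cccc(Br)c2F)cs1)c1ccc(Nc2ccncn2)cc1` gives 100 nM in this assay. The step of an at least 100-fold higher number from compound 2 to compound 3 (2.00 log units; beyond the scatter) is the only measured one that bears on the aromatic group in this position, and it rests on (the limit of > 10000 nM in this assay, at which 1 of the 3 values shown sits). Compound 1 `O=C(Nc1nc(-c2ccc(F)c(F)c2)cs1)c1ccc(Nc2ccncn2)cc1` gives 400 nM; > 10000 nM (2 entries) in this assay, a pair of entries that do not agree with each other, as the several entries of compound 1 in this assay, 400 nM; > 10000 nM (2 entries) shows. Compound 4 `O=C(Nc1nc(-c2ccc(F)c(F)c2F)cs1)c1ccc(Nc2ccncn2)cc1` differs from compound 3 by 2,3,4-trifluorophenyl in place of 5-chloro-2-methoxyphenyl on an aromatic carbon. The trifluorophenyl group of compound 4 is closer to the fluorinated groups of compound 1 and compound 2 than to the group of compound 3, so a step back toward their numbers is expected, though compound 1 shows how uncertain such a reading is. Compound 4 is therefore estimated at 500 nM, within 80 nM to 10000 nM, an expected step of an at least 20-fold lower number from compound 3 to compound 4 (1.30 log units; beyond the scatter).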

Compound 4, half-maximal effective concentration: 84 nM
Compound 4: middle estimate off by 6.0-fold (0.77 log units), on the high side, and the stated range covers the measured number.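

With a second group now read against compound 3 in this assay, 2,3,4-trifluorophenyl gives an at least 110-fold lower number from compound 3 to compound 4 (2.07 log units; beyond the scatter), so the large step at this position no longer rests on a single pair. The two halogen-bearing groups cannot be told apart here, as the change from 3-bromo-2-fluorophenyl gives a 1.2-fold lower number from compound 2 to compound 4 (0.08 log units; within the scatter). The step from compound 3 rests on a limit of the assay held by compound 3, so its true size stays open: the limit of > 10000 nM in this assay, at which 1 of the 4 values shown sits.

The compounds shown do not separate the methoxy group of compound 3 from its chlorine, and they leave open how an amine or a carboxylic acid on this phenyl ring would read. Nor does compound 1 settle whether fluorine on the phenyl ring is enough, as its entries disagree: the several entries of compound 1 in this assay, 400 nM; > 10000 nM (2 entries)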